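Two inactive chromenones and a thiadiazole analogue awaiting test

The source may hold more compounds than are shown below. What is called first, only, known or untested is meant among the compounds shown, and "the series" means these compounds.

Measured compounds:
compound 1 `Cc1ccc2oc(CSc3nc4nc(C)cc(C)n4n3)cc(=O)c2c1`, > 25000 nM
compound 2 `Cc1nnc(SCc2cc(=O)c3cc(Cl)ccc3o2)o1`, > 25000 nM

Compound 1 `Cc1ccc2oc(CSc3nc4nc(C)cc(C)n4n3)cc(=O)c2c1` was tested in a functional assay on HeLa cells (Homo sapiens) for cytotoxicity, read by MTT assay, with a stated time of 72 h (a higher number here means a weaker inhibitor, a lower number a stronger inhibitor), and gave only a limit, > 25000 nM. Compound 2 `Cc1nnc(SCc2cc(=O)c3cc(Cl)ccc3o2)o1` likewise gave only a limit in this assay, namely > 25000 nM. Both values therefore sit at the limit of > 25000 nM in this assay, at which 2 of the 2 values shown sit, so no ordering between compound 1 and compound 2 can be read from them, and compound 2 stands simply at the limit with no number of its own.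

Compound 3 `Nc1nnc(SCc2cc(=O)c3cc(Cl)ccc3o2)s1` has not yet been measured in this assay. It differs from compound 2 at one place: 5-amino-1,3,4-thiadiazol-2-yl in place of 5-methyl-1,3,4-oxadiazol-2-yl on a sulfur. Among the measured compounds shown here, no measured step of this kind exists here, so nothing shows which way such a swap moves the read-out. With both measured compounds at the limit, the step from compound 2 to compound 3 is expected to be none beyond the scatter, a step that the limit leaves unreadable from compound 2 to compound 3. Compound 3 is accordingly expected to give about 30000 nM, within 8000 nM to 120000 nM, most likely again reported as a limit.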

Compound 3, half-maximal inhibitory concentration: > 25000 nM
Compound 3 gave a limit, no number; the forecaster's own chance of this, stated with the estimate: 80%; the middle value is on the limit's open side.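

In this assay, compound 3 gave only a limit, > 25000 nM. Compound 2 gave a limit as well, so no step can be read between compound 2 and compound 3, and both stand with compound 1 at one value: the limit of > 25000 nM in this assay, at which 3 of the 3 values shown sit. The compounds shown leave open whether any group on the sulfur changes the read-out at all.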